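Moving a methyl on a pyrazole ring in a kinase inhibitor series

A few compounds are considered here, and "the series" means these few. Any claim that something is new, unique, unknown or untested is made for them only; others in the source may bear on it.

Measured so far:
- Compound 1 `Cc1c(Nc2nc(N)c3c(C#N)c(N4CCC[C@H]4C)n(C)c3n2)cnn1C`: 3 nM
- Compound 2 `CN(C)c1c(C#N)c2c(N)ncnc2n1C`: 259 nM

In an assay on isolated protein for binding affinity to Leucine-rich repeat serine/threonine-protein kinase 2 variant G2019S (Homo sapiens), read by TR-FRET and LanthaScreen, with a stated time of 2 h (on this read-out higher numbers stand for weaker inhibition and lower numbers for stronger inhibition), compound 1 gives 3 nM, the lowest of the two numbers, and compound 2 gives 259 nM, a far higher number whose gap to compound 1 lies well beyond the usual scatter. For the measured compounds named here, no step between two measured compounds that differ in only one place is available, so the effect of a small change at one position has not yet been seen directly.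

Compound 3 `Cc1nn(C)cc1Nc1nc(N)c2c(C#N)c(N3CCC[C@H]3C)n(C)c2n1` differs from compound 1 only in where one methyl sits on the pyrazole ring: 1,3-dimethyl-1H-pyrazol-4-yl in place of 1,5-dimethyl-1H-pyrazol-4-yl on a nitrogen on an aromatic ring. Going by the values given here, since no measured pair shows what such a shift does here, the expectation is a modest step in this assay, more likely toward a higher number, of about a 3.3-fold higher number from compound 1 to compound 3 (0.52 log units; beyond the scatter). Compound 3 is therefore expected to give roughly 10 nM, within a range of 3 nM to 40 nM.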

Compound 3, inhibition constant: 2 nM
Compound 3: the middle estimate sits 5.0-fold (0.70 log units) above what was measured, and the stated range ends above it.
By their numbers in this assay, from the lowest: compounds 3 and 1 (each within the scatter of the next); then compound 2.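

In this assay, moving the methyl from 1,5-dimethyl-1H-pyrazol-4-yl to 1,3-dimethyl-1H-pyrazol-4-yl gives a 1.5-fold lower number from compound 1 to compound 3 (0.18 log units; within the scatter) and so leaves the two compounds indistinguishable in this measurement. For the compounds shown here, this is the first direct view of a single change in this set, and it shows that the methyl can sit in either place on the pyrazole ring without any measurable loss of binding. No other data bear on this result or offer an explanation for it.

The compounds shown leave open whether the ring needs both methyl groups, as a 1-methyl-1H-pyrazol-4-yl group carrying only one would test. They also leave open how much room this position allows for something larger, such as an ethyl or a phenyl group in place of the methyl.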